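Quaternary ammonium analogue in the bile acid transporter series

The compounds below may be only part of what the source reports. "The series", "measured", "known", "first", "only" and "open" are said of these compounds alone.

Compound 1 `CCCC[C@]1(CC)CS(=O)(=O)c2ccc(N(O)C(=O)OC(C)(C)C)cc2[C@@H](c2ccccc2)[C@H]1O`: 2670 nM
Compound 2 `CCCC[C@]1(CC)CS(=O)(=O)c2ccc(N(C)C)cc2[C@@H](c2ccccc2)[C@H]1O`: 5 nM

In an assay on cells for inhibition of ileal sodium/bile acid cotransporter (Homo sapiens) (on this read-out lower numbers stand for stronger inhibition and higher numbers for weaker inhibition), compound 1 gives 2670 nM and compound 2 gives 5 nM. For the measured compounds named here, compound 2 stands at the lowest of the two numbers; the only neighbour is compound 1, which lies a 530-fold lower number from compound 1 to compound 2 (2.73 log units; beyond the scatter) away, with the nearer dimethylamino giving the lower number.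

Compound 3 `CCCC[C@]1(CC)CS(=O)(=O)c2ccc([N+](C)(C)C)cc2[C@@H](c2ccccc2)[C@H]1O` is not yet measured. It differs from compound 2 by a group of 4 heavy atoms (3 carbon, 1 nitrogen; no ring) in place of a group of 3 heavy atoms (2 carbon, 1 nitrogen; no ring), on an aromatic carbon, at the position on the six-membered aromatic ring of the shared core that is meta to a fused ring and para to a fused ring. Going by the values given here, the single measured step, a 530-fold lower number from compound 1 to compound 2 (2.73 log units; beyond the scatter), changes the group at this same position but exchanges a different pair of groups, so it only shows that this position can move the read-out strongly. Among the compounds with values here, no measured pair shows what a net positive charge does here. The expectation is a move back toward weaker inhibition, smaller than the measured step, with wide uncertainty.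

Compound 3 is expected to give 20 nM, within 3 nM to 150 nM. This estimate corresponds to an expected step of a 4.0-fold higher number from compound 2 to compound 3 (0.60 log units; beyond the scatter).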

Compound 3, half-maximal inhibitory concentration: 83 nM
For compound 3 the middle estimate is 4.2-fold (0.62 log units) below the measured one; measured number inside the range.
By their numbers in this assay, from the lowest: compound 2; then compound 3; then compound 1.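

In this assay, the position meta to a fused ring and para to a fused ring accepts a group with net charge +1 only at a cost, a 17-fold higher number from compound 2 to compound 3 (1.22 log units; beyond the scatter), and this step is larger than the opening estimate allowed for in its middle value. The charged group still gives a much lower number than hydroxy(tert-butoxycarbonyl)amino, a 32-fold lower number from compound 1 to compound 3 (1.51 log units; beyond the scatter), so the three groups at this position now rank dimethylamino, then the charged group, then hydroxy(tert-butoxycarbonyl)amino. The change from compound 2 to compound 3 alters the net charge, the hydrogen-bond acceptor count and the heavy atom count together, and no accompanying data separate these differences or explain the step.

A tert-butyl group at this position, with a similar heavy atom count and no net charge, would help separate the contribution of size from that of charge, while a primary amine or methylamino group would extend the neutral side of the comparison. On these data alone, it also remains open how a longer chain on the charged nitrogen, or a carboxylic acid carrying the opposite charge, would read in this assay.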